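The compounds below may be only part of what the source reports. "The series", "measured", "known", "first", "only" and "open" are said of these compounds alone.

Of the compounds shown here, three built on a common core have been tested in a functional assay on SR cells (Homo sapiens) for inhibition; a lower number here means a stronger inhibitor of growth, a higher number a weaker inhibitor of growth. Compound 1 `COc1cccc(/C=C/c2ccc(S(N)(=O)=O)cc2)c1` gives 5210 nM, compound 2 `NS(=O)(=O)c1ccc(/C=C/c2ccc(F)cc2)cc1` gives 10500 nM, and compound 3 `NS(=O)(=O)c1ccc(/C=C/c2ccc(O)c(O)c2)cc1` gives 12700 nM. Compound 2 has the second highest of these three numbers, yet both gaps lie within the scatter: compound 3 is nearest, compound 1 furthest, so none of the three can be set apart with confidence. Compound 4 `CN(C)c1ccc(/C=C/c2ccc(S(N)(=O)=O)cc2)cc1` has not yet been measured in this assay. It differs from compound 2 in a single place: dimethylamino in place of fluoro on an aromatic carbon. Among the measured compounds shown here, no step between measured compounds shows what such a change does, so only a small step is expected, barely beyond the scatter if at all, leaning toward a lower number. Compound 4 is therefore estimated at 6000 nM in this assay, somewhere between 2000 nM and 18000 nM. The expected step is a 1.8-fold lower number from compound 2 to compound 4 (0.24 log units; within the scatter).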

Compound 4, concentration for 50% growth inhibition: 8580 nM
Beside the measured number, compound 4's estimate is 1.4-fold (0.16 log units) below it, within the range that was stated.
By their numbers in this assay, from the lowest: compounds 1, 4, 2 and 3 (each within the scatter of the next, the first and the last beyond it).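

Among the compounds shown here, putting dimethylamino in place of fluoro on this aromatic carbon, para to a large group, gives the first single-place step in this assay: a 1.2-fold lower number from compound 2 to compound 4 (0.09 log units; within the scatter). At this position, then, a group of 3 heavy atoms with a hydrogen-bond acceptor and a single fluorine give numbers that cannot be told apart. No measurement shown offers an explanation for this result.

As far as these compounds go, whether a carboxylic acid, a primary amine or a longer alkyl chain on this carbon would give a step beyond the scatter remains open.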